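Ethoxy to difluoromethoxy: expected half-life of compound 3

A few compounds are considered here, and "the series" means these few. Any claim that something is new, unique, unknown or untested is made for them only; others in the source may bear on it.

Measured so far in an in vitro ADME assay on microsomes (Homo sapiens) for metabolic stability; a higher number here means that the compound lasts longer, a lower number that the compound disappears faster:
- compound 1 `CCc1nc(NC(CC)CC)c(OC)nc1-c1ccc(OC(F)F)cc1Cl` gives 2 h
- compound 2 `CCOc1ccc(-c2nc(OC)c(NC(CC)CC)nc2C)c(Cl)c1` gives 2 h

In this assay compound 2 stands at 2 h and is level with compound 1 within the scatter. Compound 3 `CCC(CC)Nc1nc(C)c(-c2ccc(OC(F)F)cc2Cl)nc1OC` has not yet been measured. It differs from compound 2 by the change ethoxy to difluoromethoxy (difluoromethyl in place of ethyl on an oxygen on an aromatic ring), which is difluoromethyl in place of ethyl on an oxygen on an aromatic ring.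

Going by the values given here, no measured pair shows this change on its own, so the expectation rests on the structural change and on compound 2 at 2 h as the starting level. A small rise in this assay is expected, and it may not exceed the scatter. The estimated move is a 1.3-fold higher number from compound 2 to compound 3 (0.10 log units; within the scatter) and no larger than that. The expected half-life of compound 3 is 2.5 h within an estimated range of 1.2 h to 5.5 h for now.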

Compound 3, half-life: 2 h
Estimate against measurement, compound 3: 1.3-fold (0.10 log units) above, within the range that was stated.
By their numbers in this assay, from the lowest: compounds 1, 2 and 3 (each within the scatter of the next).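

In this assay, going by these compounds alone, difluoromethyl in place of ethyl on an oxygen on an aromatic ring gives no change at the digits printed from compound 2 to compound 3 (within the scatter), the first direct reading of this change. Hydrogen in place of methyl on a saturated chain carbon bound to an aromatic carbon gives no change at the digits printed from compound 1 to compound 3 (within the scatter), so neither of these two places separates the three compounds in this read-out. No supporting data accompany these results to account for this.

As far as these compounds go, each step rests on one pair, so it remains open whether either holds with other groups on the shared core. Also open, from the compounds shown here alone, is whether trifluoromethyl or a longer chain on that oxygen, or an amine there in place of the whole ether, would move the half-life beyond the scatter.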